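Homologating the Amide Substituent on a PLK2 Inhibitor

The compounds below may be only part of what the source reports. "The series", "measured", "known", "first", "only" and "open" are said of these compounds alone.

Two closely related compounds have been measured in an assay for inhibition of serine/threonine-protein kinase PLK2 (Homo sapiens), read by FRET and Z'-LYTE, with a stated time of 1 h; a higher number here means a weaker inhibitor, a lower number a stronger inhibitor. Compound 1, with structure `CCC1C(=O)N(C)c2cnc(-n3ccc4cc(C(=O)NC)ccc43)nc2N1c1ccn(C)n1`, gives 218 nM. Compound 2, with structure `CCNC(=O)c1ccc2c(ccn2-c2ncc3c(n2)N(c2ccn(C)n2)C(CC)C(=O)N3C)c1`, differs only in carrying a methyl in place of hydrogen on a saturated chain carbon bound to an amide-type nitrogen, and in this assay compound 2 gives 243 nM. The step of a 1.1-fold higher number from compound 1 to compound 2 (0.05 log units; within the scatter) is small, so these two values sit within the scatter of each other; compound 2 has only compound 1 to be compared with, and nothing separates them beyond the noise of the measurement.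

Compound 3, with structure `CCC1C(=O)N(C)c2cnc(-n3ccc4cc(C(=O)NCC(C)C)ccc43)nc2N1c1ccn(C)n1`, continues along the same line: isopropyl in place of methyl on a saturated chain carbon bound to an amide-type nitrogen. Going by the values given here, the only measured step that bears on this change is the one from compound 1 to compound 2, at the same place, and it stayed within the scatter. A larger group enters here, but the evidence offers no sign of a shift in either direction. Compound 3 is therefore expected to give 260 nM, with a range from 120 nM to 560 nM. The expected step of a 1.1-fold higher number from compound 2 to compound 3 (0.03 log units; within the scatter) lies within the scatter.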

Compound 3, half-maximal inhibitory concentration: 159 nM
Estimate against measurement, compound 3: 1.6-fold (0.21 log units) above; the range from low to high includes it.
By their numbers in this assay, from the lowest: compounds 3, 1 and 2 (each within the scatter of the next).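

The isobutylcarbamoyl group of compound 3 is the first branched group shown at this position, and it enters with more carbon than the ethyl it replaces. In this assay, that replacement gives a 1.5-fold lower number from compound 2 to compound 3 (0.18 log units; within the scatter) and the comparison with the methyl amide gives a 1.4-fold lower number from compound 1 to compound 3 (0.14 log units; within the scatter) so neither step separates the compounds from one another. Methyl, ethyl and isobutyl on the amide nitrogen therefore all give values within the scatter of each other, which shows that this position accepts a branched group as well as the two small straight ones, with no measurable gain or loss, although nothing available here accounts for this result.

These three compounds all carry plain carbon chains, so they leave open whether the position would also accept a chain ending in an amine or a carboxylic acid, a ring such as cyclohexyl, or a much longer chain such as n-octyl. They also leave open what would happen if the amide hydrogen itself were replaced, since all three compounds keep it.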